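The compounds below may be only part of what the source reports. "The series", "measured", "known", "first", "only" and "open" are said of these compounds alone.

Measured so far in a functional assay on CNE-2 cells (Homo sapiens) for inhibition, read by MTT assay, with a stated time of 72 h; on this read-out lower numbers stand for stronger inhibition and higher numbers for weaker inhibition:
compound 1 `CNC(=O)CCCCCCCn1nc(-c2cnc3[nH]ccc3c2)c2c(N)ncnc21` gives 8990 nM
compound 2 `Nc1nc2cc(-c3nn(CCCCCC(=O)NO)c4ncnc(N)c34)ccc2o1` gives 37600 nM

Compound 2 holds the higher of the two numbers, and its gap to compound 1 lies beyond the usual scatter. Compound 3 `CNC(=O)CCCCCCCn1nc(-c2ccc3oc(N)nc3c2)c2c(N)ncnc21` has not yet been measured. It differs from compound 2 by one change: 2-(methylcarbamoyl)ethyl in place of hydroxycarbamoyl on a saturated chain carbon, five bonds along the chain from an aromatic nitrogen. Among the compounds with values here, no measured pair shows this change alone, so any expectation is loose. Compound 1 also holds the 2-(methylcarbamoyl)ethyl group, and at 8990 nM it sits lower, so a moderate step towards lower numbers is expected in this assay for compound 3. The expected step is a 3.1-fold lower number from compound 2 to compound 3 (0.50 log units; beyond the scatter) and remains only an estimate. For compound 3 the estimated value is 12000 nM with an expected range from 3000 nM to 50000 nM in this read-out.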

Compound 3, half-maximal inhibitory concentration: 2250 nM
The estimate for compound 3 lay 5.3-fold (0.73 log units) above the measured number, outside the stated range (below it).
By their numbers in this assay, from the lowest: compound 3; then compound 1; then compound 2.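

In this assay, putting 2-(methylcarbamoyl)ethyl in place of hydroxycarbamoyl on a saturated chain carbon, five bonds along the chain from an aromatic nitrogen, gives a 17-fold lower number from compound 2 to compound 3 (1.22 log units; beyond the scatter). This shows that the chain end strongly affects the read-out and that hydroxycarbamoyl is not required for the lowest number among these compounds. With that chain held constant, the aromatic group on the shared core also counts, though less, giving a 4.0-fold lower number from compound 1 to compound 3 (0.60 log units; beyond the scatter). No measurement shown here accounts for either step.

The step from compound 2 to compound 3 changes the end group and the chain length together, so their separate contributions remain unresolved. A carboxylic acid or a primary amide at the chain end, or a longer chain ending in hydroxycarbamoyl, could separate them.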